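This account rests on a few compounds, and the source may have more. Where it says the series, first, only, none or still open, it means among the compounds named here.

Measured set in an assay on isolated protein for inhibition of Nicotinamide phosphoribosyltransferase (Homo sapiens), read by spectrophotometry, with stated times of 15 min and 30 min; on this read-out higher numbers stand for weaker inhibition and lower numbers for stronger inhibition:
compound 1 `Cc1ncccc1CNC(=O)Nc1ccc(S(=O)(=O)c2ccccc2)cc1` gives 146 nM
compound 2 `Cc1cncc(CNC(=O)Nc2ccc(S(=O)(=O)c3ccccc3)cc2)c1` gives 7 nM
compound 3 `C[C@@H]1COC[C@@H](C)N1S(=O)(=O)c1ccc(NC(=O)NCc2cccnc2)cc1` gives 52 nM

Compound 3 stands second highest of the three numbers: against compound 1 it is lower, and against compound 2 it is higher, both gaps beyond the scatter. Going by the values given here, the only single-point step measured so far, a 21-fold lower number from compound 1 to compound 2 (1.32 log units; beyond the scatter), concerns the methylpyridinyl group on the saturated chain carbon and leaves the sulfonyl side untouched; it therefore gives no direct guide to the change now in question.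

Compound 4 `CC1CCN(S(=O)(=O)c2ccc(NC(=O)NCc3cccnc3)cc2)CCN1` differs from compound 3 only on the sulfonyl sulfur: a group of 8 heavy atoms (6 carbon, 2 nitrogen; one seven-membered non-aromatic ring with 2 hetero atoms) in place of a group of 8 heavy atoms (6 carbon, 1 nitrogen, 1 oxygen; one six-membered non-aromatic ring with 2 hetero atoms), on a sulfonyl sulfur. Among the compounds with values here, no measured pair in this set varies the group on the sulfonyl sulfur while holding the rest constant, so the size of this step is unknown from the data. The expectation for compound 4 is accordingly a number close to that of compound 3, with a step of a 1.3-fold higher number from compound 3 to compound 4 (0.13 log units; within the scatter) not clearly beyond the scatter in either direction. On that basis compound 4 is estimated at 70 nM in this assay, within a range of 15 nM to 300 nM.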

Compound 4, half-maximal inhibitory concentration: 11 nM
The estimate for compound 4 lay 6.4-fold (0.80 log units) above the measured number; measured number outside the range, below it.
By their numbers in this assay, from the lowest: compounds 2 and 4 (each within the scatter of the next); then compound 3; then compound 1.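

In this assay the group on a sulfonyl sulfur now has a measured effect: a 4.7-fold lower number from compound 3 to compound 4 (0.67 log units; beyond the scatter), when 3,5-dimethylmorpholin-4-yl gives way to the seven-membered non-aromatic ring with 2 hetero atoms. The two groups have the same heavy-atom count, so that count alone does not set the number at this place, and the change also alters ring size, swaps oxygen for nitrogen, adds a hydrogen-bond donor and removes the 2 defined stereocentres. No measured evidence accounts for this step.

Which of these differences carries the step stays open, and an unsubstituted piperazine or a morpholine without methyl groups on the sulfonyl sulfur would help separate them. Also open, from the compounds shown here alone, is whether the 5-methylpyridin-3-yl group of compound 2 would combine with the seven-membered ring of compound 4.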